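The source may report more compounds than this note shows. Statements on the series, on what has been measured and on what is new or still open speak of the compounds shown alone.

Measured so far in an ADME assay on CHO cells (Cricetulus griseus) for cytotoxicity, read by MTT assay, with a stated time of 24 h; on this read-out lower numbers stand for higher toxicity in this test and higher numbers for lower toxicity in this test:
- Compound 1 `CC1Cn2cc([N+](=O)[O-])nc2O1`: > 500000 nM
- Compound 2 `Cc1ccc(-c2c([N+](=O)[O-])nc3n2CC(C)O3)cc1`: > 250000 nM
- Compound 3 `Cc1ccc(-c2c([N+](=O)[O-])nc3n2CC(C)O3)s1`: > 125000 nM

All three entries are limits of the assay and not exact numbers, so compound 3 has a limit and no exact value. Compound 4 `CC1Cn2c(nc([N+](=O)[O-])c2C#CC2CC2)O1` carries 2-cyclopropylethynyl in place of the 5-methylthiophen-2-yl of compound 3: 2-cyclopropylethynyl in place of 5-methylthiophen-2-yl on an aromatic carbon. Among the measured compounds shown here, the one measured step that bears on this is a step that the two limits leave unreadable from compound 1 to compound 3. No step beyond the usual scatter is expected in this assay, since this guide gives no readable size. The expected change is a step that the limit leaves unreadable from compound 3 to compound 4. For compound 4 the estimate is 150000 nM, with an expected range from 50000 nM to 500000 nM. The result may well arrive only as a limit.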

Compound 4, half-maximal cytotoxic concentration: 6450 nM
The estimate for compound 4 lay 23-fold (1.37 log units) above the measured number; measured number outside the range, below it.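

In this assay, 2-cyclopropylethynyl on this aromatic carbon gives an at least 19-fold lower number from compound 3 to compound 4 (1.28 log units; beyond the scatter), and it gives an at least 77-fold lower number from compound 1 to compound 4 (1.88 log units; beyond the scatter). Among the compounds shown here, compound 4 thus has the first exact value, and it shows that this position can shift the read-out towards higher toxicity in this test, which the limits of the earlier compounds could not show. The first step starts from a limit, so its true size may be larger: the limit of > 125000 nM in this assay, at which 1 of the 4 values shown sits.

The compounds shown leave open whether the triple bond or the three-membered ring drives the change. A straight butyl chain or an amine at this carbon could help separate these possibilities.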